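A few compounds are considered here, and "the series" means these few. Any claim that something is new, unique, unknown or untested is made for them only; others in the source may bear on it.

Measured compounds in a functional assay on PC-3 cells (Homo sapiens) for inhibition, read by sulforhodamine B assay, with a stated time of 72 h; on this read-out higher numbers stand for weaker inhibition and lower numbers for stronger inhibition:
- compound 1 `CC1CN(C(=O)c2c(N)sc(-c3ccc(Cl)cc3)c2-c2ccc(Cl)cc2)CCN1`: 7210 nM
- compound 2 `Nc1sc(-c2ccc(Cl)cc2)c(-c2ccc(Cl)cc2)c1C(=O)NCc1ccccc1`: 31800 nM

Compound 1 holds the lowest of the two numbers in this assay; its nearest neighbour is compound 2, reached by a 4.4-fold higher number from compound 1 to compound 2 (0.64 log units; beyond the scatter), a modest step that lies beyond the scatter.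

Compound 3 `COC(=O)c1c(N)sc(-c2ccc(Cl)cc2)c1-c1ccc(Cl)cc1` is not yet measured in this assay. It differs from compound 1 in one place: methoxy in place of 3-methylpiperazin-1-yl on a carbonyl carbon.

Within the data shown here, the only measured step that bears on this change is a 4.4-fold higher number from compound 1 to compound 2 (0.64 log units; beyond the scatter), where the 3-methylpiperazin-1-yl group on the carbonyl carbon was likewise replaced, there by benzylamino, and the number rose. The methoxy group of compound 3 is smaller than either group, so the same direction is expected but with wide uncertainty. The step is expected to read a 2.8-fold higher number from compound 1 to compound 3 (0.44 log units; beyond the scatter), a rise.

For compound 3 in this assay the estimate is 20000 nM, within 6000 nM to 70000 nM.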

Compound 3, half-maximal inhibitory concentration: 2780 nM
Beside the measured number, compound 3's estimate is 7.2-fold (0.86 log units) above it, outside the stated range (below it).
By their numbers in this assay, from the lowest: compound 3; then compound 1; then compound 2.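

At this carbonyl carbon, methoxy gives stronger inhibition in this assay than 3-methylpiperazin-1-yl (a 2.6-fold lower number from compound 1 to compound 3 (0.41 log units; beyond the scatter)), so the six-membered ring and the hydrogen-bond donor that leave with that group are not needed for activity in this series. The gap to benzylamino is wider (an 11-fold lower number from compound 2 to compound 3 (1.06 log units; beyond the scatter)), and methoxy now gives the lowest number of the three groups compared at this carbon. No measurement here accounts for this order.

Methoxy is the only group shown at this carbon that is joined through oxygen, so it remains open whether the lower number is specific to methoxy or is shared by other groups joined in this way. On these data alone, an ethoxy group, a carboxylic acid and a dimethylamino group at the same carbon remain open as comparisons.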